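This account rests on a few compounds, and the source may have more. Where it says the series, first, only, none or still open, it means among the compounds named here.

Measured in a physicochemical assay for lipophilicity, measured as octanol-water partition; on this read-out higher numbers stand for higher lipophilicity and lower numbers for lower lipophilicity:
- compound 1 `CCCCCc1cn(CC=C(C)C)nn1`: 3.46
- compound 2 `CCCCCc1cn(C/C=C(\C)CCC=C(C)C)nn1`: 5.45
- compound 3 `CCCCCc1cn(C/C=C(/C)CCC=C(C)C)nn1`: 5.45

Compound 1 holds the lowest of the three numbers in this assay. The measured steps away from it are a number 1.99 log units higher from compound 1 to compound 2 (beyond the scatter) and a number 1.99 log units higher from compound 1 to compound 3 (beyond the scatter). The remaining step is no change at the digits printed from compound 2 to compound 3 (within the scatter), and given (the fact that compounds 2 and 3 differ only in the configuration as drawn), compound 3 adds no separate guide on size.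

Compound 4 `CCCc1cn(CC=C(C)C)nn1` is not yet measured. It keeps the core of compound 1 and carries propyl where compound 1 carries pentyl: hydrogen in place of ethyl on a saturated chain carbon, three bonds along the chain from an aromatic carbon. In words, this is hydrogen in place of ethyl on a saturated chain carbon, three bonds along the chain from an aromatic carbon.

Among the compounds with values here, no measured step touches this chain, so the only guide on size is the addition of 3-methylbut-2-en-1-yl, at another place, in a number 1.99 log units higher from compound 1 to compound 2 (beyond the scatter). Here a smaller group, ethyl, leaves rather than a larger one entering, so a step in the opposite direction and of smaller size is expected, though still beyond the scatter. The expected step is a number 0.86 log units lower from compound 1 to compound 4 (beyond the scatter). For compound 4 the estimate is 2.6, with an expected range of 2.25 to 2.95.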

Compound 4, partition coefficient: 2.47
Compound 4: the middle estimate sits 0.13 log units above what was measured; low and high end bracket the measured number.
By their numbers in this assay, from the lowest: compound 4; then compound 1; then compounds 2 and 3 (each within the scatter of the next).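

Within this assay, hydrogen in place of ethyl on a saturated chain carbon, three bonds along the chain from an aromatic carbon, gives a number 0.99 log units lower from compound 1 to compound 4 (beyond the scatter), and this makes pentyl to propyl the first change shown at this chain, which stays the same throughout compound 1, compound 2 and compound 3. The earlier change, at the other substituent of the shared core, gave a number 1.99 log units higher from compound 1 to compound 2 (beyond the scatter), so the read-out now responds to a change at two separate places, and removing ethyl here gives a step printed as modest against one printed as large for adding 3-methylbut-2-en-1-yl there. Nothing on record bears on the cause of the pentyl to propyl step.

With only pentyl and propyl shown, this chain has just two points, so the course of the read-out through butyl or a longer chain such as heptyl stays open. Also open, on these data alone, are how an amine or a carboxylic acid in place of this chain would read in this assay, and whether the same shortening would give a step of similar size on compound 2.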